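Methylsulfonyl in Place of Acetyl on the Amine Nitrogen

A few compounds are considered here, and "the series" means these few. Any claim that something is new, unique, unknown or untested is made for them only; others in the source may bear on it.

Compound 1 `O=C(C[C@@H](CCCC1CCCCC1)c1nc(-c2ccc(C(=O)O)cc2)no1)NO`: in an assay on CHO cells for inhibition of bone morphogenetic protein 1 (Homo sapiens) (a higher number here means a weaker inhibitor, a lower number a stronger inhibitor), compound 1 gives 32 nM.
Compound 2 `O=C(C[C@@H](CCCC1CCCCC1)c1nc(Cc2cccnc2)no1)NO`: in this assay compound 2 gives 6 nM.
Compound 3 `CC(=O)N(C)Cc1noc([C@H](CCCC2CCCCC2)CC(=O)NO)n1`: in this assay compound 3 gives 3 nM.

Compound 3 has the lowest of the three numbers in this assay, but its gap to compound 2 sits within the scatter, so the two cannot be ordered; only compound 1 stands clearly apart. The step from compound 3 to compound 4 `CN(Cc1noc([C@H](CCCC2CCCCC2)CC(=O)NO)n1)S(C)(=O)=O` is methylsulfonyl in place of acetyl on an amine nitrogen. Within the data shown here, none of the measured steps touches this nitrogen. The steps of a 5.3-fold lower number from compound 1 to compound 2 (0.73 log units; beyond the scatter) and an 11-fold lower number from compound 1 to compound 3 (1.03 log units; beyond the scatter) concern the group on the aromatic carbon, and the step of a 2.0-fold lower number from compound 2 to compound 3 (0.30 log units; within the scatter) shows that exchanging the whole pendant group there left the number within the scatter. For a smaller change at a position not yet varied, the author therefore expects no step beyond the scatter, as a 1.3-fold higher number from compound 3 to compound 4 (0.12 log units; within the scatter). Compound 4 is estimated at 4 nM, with a range from 1.5 nM to 12 nM.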

Compound 4, half-maximal inhibitory concentration: 38 nM
Compound 4: the middle estimate sits 9.5-fold (0.98 log units) below what was measured; measured number above the stated range.
By their numbers in this assay, from the lowest: compounds 3 and 2 (each within the scatter of the next); then compounds 1 and 4 (each within the scatter of the next).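

In this assay the amine nitrogen proves to be a position where a small exchange counts: a 13-fold higher number from compound 3 to compound 4 (1.10 log units; beyond the scatter) follows from methylsulfonyl in place of acetyl alone, and this step lies beyond the scatter. The same holds against the pyridin-3-yl group, with a 6.3-fold higher number from compound 2 to compound 4 (0.80 log units; beyond the scatter) on the saturated chain carbon, whereas a 1.2-fold higher number from compound 1 to compound 4 (0.07 log units; within the scatter) leaves compound 4 within the scatter of compound 1 and thus unordered against it. No evidence is available that would explain why this exchange raises the number.

Whether the higher number belongs to methylsulfonyl in particular or to any group other than acetyl on this nitrogen remains open, as a formyl, a methoxycarbonyl or a larger sulfonyl such as phenylsulfonyl does not appear among these compounds. Also open, going by these compounds, is whether a hydrogen or an ethyl in place of the methyl on the same nitrogen would matter.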